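A few compounds are considered here, and "the series" means these few. Any claim that something is new, unique, unknown or untested is made for them only; others in the source may bear on it.

Compound 1, `Cc1cc(=O)n(-c2ccc(Br)cc2F)nc1C(=O)Nc1ccc(Oc2ncnc3[nH]ccc23)cc1`, is the reference; in a functional assay on HepG2 cells (Homo sapiens) for cytotoxicity, read by MTT assay, with a stated time of 72 h (a higher number here means a weaker inhibitor, a lower number a stronger inhibitor), compound 1 gives 3660 nM. Compound 2, `Cc1cc(=O)n(-c2cccc(C(F)(F)F)c2)nc1C(=O)Nc1ccc(Oc2ncnc3[nH]ccc23)cc1`, carries a single change at the ring nitrogen, (3-(trifluoromethyl)phenyl in place of 4-bromo-2-fluorophenyl on an aromatic nitrogen), and in this assay compound 2 gives 9470 nM, a step of a 2.6-fold higher number from compound 1 to compound 2 (0.41 log units; beyond the scatter). Compound 3, `Cc1cc(=O)n(-c2ccc(Br)cc2F)nc1C(=O)Nc1ccc(Oc2ncnc3[nH]ccc23)c(F)c1`, differs from compound 1 in the core, (fluoro in place of hydrogen on an aromatic carbon), and in this assay compound 3 gives 32000 nM, which amounts to an 8.7-fold higher number from compound 1 to compound 3 (0.94 log units; beyond the scatter). Compound 4, `Cc1cc(=O)n(-c2cccc(C(F)(F)F)c2)nc1C(=O)Nc1ccc(Oc2ncnc3[nH]ccc23)c(F)c1`, has not yet been measured. Its change from compound 3 is 3-(trifluoromethyl)phenyl in place of 4-bromo-2-fluorophenyl on an aromatic nitrogen, the same change that leads from compound 1 to compound 2, at a place described in identical terms. For compound 4 the expected step is a 2.5-fold higher number from compound 3 to compound 4 (0.40 log units; beyond the scatter), resting on the earlier step of a 2.6-fold higher number from compound 1 to compound 2 (0.41 log units; beyond the scatter) applied to the weaker core of compound 3. Compound 4 is therefore estimated at 80000 nM, likely between 30000 nM and 200000 nM.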

Compound 4, half-maximal inhibitory concentration: 26300 nM
Compound 4: the middle estimate sits 3.0-fold (0.48 log units) above what was measured, outside the stated range (below it).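

On the core of compound 3, the swap of aryl groups gives a 1.2-fold lower number from compound 3 to compound 4 (0.09 log units; within the scatter), so the rise seen on the core of compound 1 did not carry over: the same change on two cores in this assay, a 2.6-fold higher number (0.41 log units; beyond the scatter) from compound 1 to compound 2 and a 1.2-fold lower number (0.09 log units; within the scatter) from compound 3 to compound 4, 3.1-fold (0.50 log units) apart, beyond the scatter of two such steps The fluoro in place of hydrogen still gives a 2.8-fold higher number from compound 2 to compound 4 (0.44 log units; beyond the scatter), the same direction as on the core of compound 1 but a smaller step: the same change on two cores in this assay, an 8.7-fold higher number (0.94 log units; beyond the scatter) from compound 1 to compound 3 and a 2.8-fold higher number (0.44 log units; beyond the scatter) from compound 2 to compound 4, 3.1-fold (0.50 log units) apart, beyond the scatter of two such steps In this assay the two changes therefore do not add independently across these four compounds, but this rests on a single square of compounds and does not show why the steps differ.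

Still open, as far as these compounds go, is whether the same holds for an aryl group carrying a methoxy or an amine on the aromatic nitrogen. Also open, from the compounds shown here alone, is how a chloro or a methyl would behave in place of the fluoro on the core.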